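Aryl swaps on the saturated ring carbon: working notes

The source may hold more compounds than are shown below. What is called first, only, known or untested is meant among the compounds shown, and "the series" means these compounds.

Compound 1 `CC(=O)N1N=C(c2cc(O)c(O)c([N+](=O)[O-])c2)CC1c1ccco1`, compound 2 `CC(=O)N1N=C(c2cc(O)c(O)c([N+](=O)[O-])c2)CC1c1ccoc1` and compound 3 `CC(=O)N1N=C(c2cc(O)c(O)c([N+](=O)[O-])c2)CC1c1cccs1` share one core and differ only in the aryl group on the saturated ring carbon. In an assay on isolated protein for inhibition of Amine oxidase [flavin-containing] B (Homo sapiens), read by fluorescence (on this read-out higher numbers stand for weaker inhibition and lower numbers for stronger inhibition), compound 1 gives 77400 nM, compound 2 gives 126000 nM and compound 3 gives 69200 nM. Compound 3 has the lowest of the three numbers, but all three sit close together: a 1.1-fold lower number from compound 1 to compound 3 (0.05 log units; within the scatter), a 1.8-fold lower number from compound 2 to compound 3 (0.26 log units; within the scatter) and a 1.6-fold higher number from compound 1 to compound 2 (0.21 log units; within the scatter). No aryl swap so far has moved this assay beyond the scatter.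

Compound 4 `CC(=O)N1N=C(c2cc(O)c(O)c([N+](=O)[O-])c2)CC1c1cccc(C#N)c1` is not yet measured. Its change from compound 3 is 3-cyanophenyl in place of thiophen-2-yl on a saturated ring carbon. Among the compounds with values here, the steps that bear on it are the two ending at compound 3, which exchanged one small heteroaryl for another at the same place and both stayed within the scatter. The entering group is a six-membered ring of carbon only carrying a nitrile, larger than anything tried at this position, so the precedent is only partial. On the numbers in hand the expectation is still no step beyond the scatter, a 1.1-fold higher number from compound 3 to compound 4 (0.03 log units; within the scatter). Compound 4 is therefore estimated at 75000 nM in this assay, with a range from 25000 nM to 220000 nM.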

Compound 4, half-maximal inhibitory concentration: 55400 nM
Estimate against measurement, compound 4: 1.4-fold (0.13 log units) above, within the range that was stated.
By their numbers in this assay, from the lowest: compounds 4, 3, 1 and 2 (each within the scatter of the next, the first and the last beyond it).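

Going from a small five-membered heteroaryl to the larger 3-cyanophenyl on the saturated ring carbon does not cost anything in this assay: there is a 1.2-fold lower number from compound 3 to compound 4 (0.10 log units; within the scatter) and a 1.4-fold lower number from compound 1 to compound 4 (0.15 log units; within the scatter), so the six-membered ring with its nitrile is tolerated here as well as thiophen-2-yl and furan-2-yl are. Within the data shown here, the one step that clears the scatter is a 2.3-fold lower number from compound 2 to compound 4 (0.36 log units; beyond the scatter), the first at this position to do so, though it is modest, holds only against furan-3-yl, and leaves compound 4 at 55400 nM, still a high number on this read-out. No measurement shown here explains this step, and the small shift from compound 2 therefore stands as an observation only.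

The ring and the nitrile enter together in compound 4, so a plain phenyl, or a 3-cyanophenyl with the nitrile replaced by an amine or a carboxylic acid, would be needed to separate their contributions. Every group shown at this position is an aromatic ring attached directly, which leaves open how a saturated ring such as piperidine, or a longer chain such as benzyl, would read in this assay.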